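The compounds below may be only part of what the source reports. "The series", "measured", "known", "first", "only" and "open" are said of these compounds alone.

In an ADME assay on TZM cells (Homo sapiens) for cytotoxicity, with a stated time of 1 days (on this read-out higher numbers stand for lower toxicity in this test and lower numbers for higher toxicity in this test), compound 3 `COCc1cc(N)c(Nc2ccc(C#N)cc2)cc1Oc1c(C)cc(CCC#N)cc1C` gives > 200000 nM, which is a limit and not a number. Compound 1 `Cc1cc(CCC#N)cc(C)c1Oc1cc(Nc2ccc(C#N)cc2)c(N)cc1C(=O)N(C)C` gives 38200 nM and compound 2 `Cc1cc(CCC#N)cc(C)c1Oc1cc(Nc2ccc(C#N)cc2)c(N)cc1CNC1CC1` gives 25500 nM, with a 1.5-fold lower number from compound 1 to compound 2 (0.18 log units; within the scatter). Compound 4 `CCOCc1cc(N)c(Nc2ccc(C#N)cc2)cc1Oc1c(C)cc(CCC#N)cc1C` carries methyl in place of hydrogen on a saturated chain carbon bound to an oxygen on a saturated carbon, turning methoxymethyl into ethoxymethyl. The measured steps that bear on this replace a whole group at the aromatic carbon: an at least 5.2-fold higher number from compound 1 to compound 3 (0.71 log units; beyond the scatter), and an at least 7.8-fold higher number from compound 2 to compound 3 (0.89 log units; beyond the scatter). Both rest on the limit of compound 3, and neither tests methyl to ethyl. No step beyond the scatter is expected in this assay, and no direction is favoured. The expected change is an at least 1.1-fold lower number from compound 3 to compound 4 (0.07 log units; that floor lies within the scatter). Compound 4 may again report only a limit. For compound 4 the estimate is 170000 nM, with an expected range of 70000 nM to 350000 nM.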

Compound 4, half-maximal cytotoxic concentration: 194000 nM
For compound 4 the middle estimate is 1.1-fold (0.06 log units) below the measured one; low and high end bracket the measured number.
By their numbers in this assay, from the lowest: compounds 2 and 1 (each within the scatter of the next); then compound 4. At a limit, above all of these: compound 3.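

In this assay, ethoxymethyl on the aromatic carbon yields a measured number rather than a limit, so the rise over the other two groups no longer rests on a limit alone (a 5.1-fold higher number from compound 1 to compound 4 (0.71 log units; beyond the scatter); a 7.6-fold higher number from compound 2 to compound 4 (0.88 log units; beyond the scatter)). Going from methoxy to ethoxy gives only a floor (an at least 1.0-fold lower number from compound 3 to compound 4 (0.01 log units; that floor lies within the scatter)), so the size of that change stays unknown. Compound 3 reports a limit and not a number: (the limit of > 200000 nM in this assay, at which 1 of the 4 values shown sits).

Open, from the compounds shown here alone, is whether a longer chain on the oxygen, such as propoxymethyl, keeps the number this high. Also open, going by these compounds, is how a hydroxymethyl or a carboxylic acid at the aromatic carbon reads.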